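The source may hold more compounds than are shown below. What is called first, only, known or untested is meant among the compounds shown, and "the series" means these compounds.

Compound 1 `O=C(CCc1ccc(-c2ccccc2)cc1)c1ncc(-c2ccncc2)o1` gives the lowest number of the three measured in an assay for inhibition of Fatty-acid amide hydrolase 1 (Rattus norvegicus) (on this read-out higher numbers stand for weaker inhibition and lower numbers for stronger inhibition), namely 2.3 nM. Compound 2 `CCOC(=O)c1cccc(-c2cnc(C(=O)CCc3ccc(-c4ccccc4)cc3)o2)n1` lies within the scatter of that result, giving 3 nM in this assay. Compound 3 `COC(=O)c1cccc(-c2cnc(C(O)CCc3ccc(-c4ccccc4)cc3)o2)n1` stands far from both, with a value in this assay of 9000 nM. Compound 4 `O=C(O)c1cc(-c2cnc(C(=O)CCc3ccc(-c4ccccc4)cc3)o2)ccn1` has not yet been measured; it differs from compound 1 in one place: carboxy in place of hydrogen on an aromatic carbon. Going by the values given here, no measured pair shows this particular change, so its effect is untested. Since compound 2, carrying an ester on its own six-membered ring, still gives 3 nM, only a modest step toward weaker inhibition, a 4.3-fold higher number from compound 1 to compound 4 (0.64 log units; beyond the scatter), is expected. Compound 4 is estimated at 10 nM, with a range from 2 nM to 60 nM.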

Compound 4, inhibition constant: 50 nM
Estimate against measurement, compound 4: 5.0-fold (0.70 log units) below; the range from low to high includes it.
By their numbers in this assay, from the lowest: compounds 1 and 2 (each within the scatter of the next); then compound 4; then compound 3.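

In this assay carboxy on the aromatic carbon next to the ring nitrogen costs clearly, with a 22-fold higher number from compound 1 to compound 4 (1.34 log units; beyond the scatter) as a large step and the first measured effect of any change at this position. Even so, compound 4 gives 50 nM and so remains an inhibitor in the nanomolar range despite the change from pyridin-4-yl to 2-carboxypyridin-4-yl. No measurement shown here accounts for the loss. On these data alone, whether a methyl ester or a primary amide at this same carbon would stay closer to compound 1 remains open, as does the effect of carboxy on another carbon of this ring.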